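Lengthening an Ether Chain on Two Related Cores

The source may report more compounds than this note shows. Statements on the series, on what has been measured and on what is new or still open speak of the compounds shown alone.

The compounds here were tested in a functional assay on the whole organism (strain Sprague-Dawley) for inhibition, with Rattus norvegicus as the target, with a stated time of 10 min; on this read-out lower numbers stand for an effect already at smaller amounts and higher numbers for an effect only at larger amounts of compound. Compound 1, `COc1ccccc1-c1ncc(C(=O)O)c(=O)[nH]1`, gives 10 mg/kg in this assay. Compound 2, `CCOc1ccccc1-c1ncc(C(=O)O)c(=O)[nH]1`, carries a single change from compound 1, (methyl in place of hydrogen on a saturated chain carbon bound to an oxygen on an aromatic ring), and in this assay compound 2 gives 0.5 mg/kg. That one change made a 20-fold lower number from compound 1 to compound 2 (1.30 log units; beyond the scatter), a step well beyond the usual scatter of such measurements.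

Compound 3, `COc1cccc(-c2ncc(C(=O)O)c(=O)[nH]2)c1`, is built from the same atoms as compound 1 joined in a different way; the difference between the two cores is not broken down here. In this assay compound 3 gives 10 mg/kg, which stands level with compound 1 within the scatter, so no order between the two can be read from these numbers.

Compound 4, `CCOc1cccc(-c2ncc(C(=O)O)c(=O)[nH]2)c1`, has not been measured. It differs from compound 3 by methyl in place of hydrogen on a saturated chain carbon bound to an oxygen on an aromatic ring, the same change that separates compound 1 from compound 2, made on the core of compound 3 instead. The step expected from this change is a 10-fold lower number from compound 3 to compound 4 (1.00 log units; beyond the scatter), and that expectation rests on a 20-fold lower number from compound 1 to compound 2 (1.30 log units; beyond the scatter). Going by the values given here, only one earlier example of the change exists, and it sits on a different core, so a somewhat smaller gain is assumed than was seen before. Compound 4 is therefore estimated to give about 1 mg/kg in this assay, most likely between 0.3 mg/kg and 5 mg/kg.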

Compound 4, dose for 50% inhibition: 5 mg/kg
The estimate for compound 4 lay 5.0-fold (0.70 log units) below the measured number; the range from low to high includes it.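

On the other core, the change from methoxy to ethoxy gave a 2.0-fold lower number from compound 3 to compound 4 (0.30 log units; within the scatter) in this assay, so on this core the step cannot be told apart from the ordinary spread of repeated measurements. Set beside the earlier step, the same small change clearly did not carry over at the same size from one core to the other: the same change on two cores in this assay, a 20-fold lower number (1.30 log units; beyond the scatter) from compound 1 to compound 2 and a 2.0-fold lower number (0.30 log units; within the scatter) from compound 3 to compound 4, 10-fold (1.00 log units) apart, beyond the scatter of two such steps. Going by these compounds alone, this shows that, in this series, a large gain from ethoxy on the core of compound 1 cannot be assumed to appear on the core of compound 3, but with only one pair of compounds on each core it does not show why the two cores differ, or how the change would behave on any further core.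

From the compounds shown here alone, it remains open whether a longer chain on the ether oxygen, such as propyl or butyl, would lower the number further on either core. Going by these compounds, it is equally open what an amine in place of the ether would do, and whether such a replacement would also depend on the core that carries it.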